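Notes on the aryl exchange from compound 2 to compound 3

The compounds below may be only part of what the source reports. "The series", "measured", "known", "first", "only" and "open" are said of these compounds alone.

The series keeps one shared core and varies only the aryl group carried on the aromatic nitrogen. Compound 1 `CCCNC(=O)c1cc(Oc2ccc(NC(=O)c3cc4cccnc4n(-c4ccc(F)cc4)c3=O)cc2)ccn1` carries a fluoro on that aryl ring, and in a functional assay on A549 cells (Homo sapiens) for antiproliferative activity, read by MTT assay, with a stated time of 72 h (a lower number here means a stronger inhibitor, a higher number a weaker inhibitor), compound 1 gives 62 nM. Compound 2 `CCCNC(=O)c1cc(Oc2ccc(NC(=O)c3cc4cccnc4n(-c4ccc(Cl)cc4)c3=O)cc2)ccn1` carries a chloro in its place, and in this assay compound 2 gives 120 nM. Going by the values given here, the only step measured so far is a 1.9-fold higher number from compound 1 to compound 2 (0.29 log units; within the scatter). Among the compounds with values here, of the two numbers known, compound 2 holds the higher one, but its distance to compound 1 is within the scatter, so no order between the two can be read from this.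

Compound 3 `CCCNC(=O)c1cc(Oc2ccc(NC(=O)c3cc4cccnc4n(-c4ccc(C(F)(F)F)cc4Cl)c3=O)cc2)ccn1` differs from compound 2 by 2-chloro-4-(trifluoromethyl)phenyl in place of 4-chlorophenyl on an aromatic nitrogen. Within the data shown here, no measured step covers a change of this kind; the one step at hand swapped one halogen for another and stayed within the scatter. On that footing the expected step is a 1.3-fold higher number from compound 2 to compound 3 (0.10 log units; within the scatter), nothing beyond the scatter. For compound 3 the estimate in this assay is 150 nM, with a range from 45 nM to 500 nM.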

Compound 3, half-maximal inhibitory concentration: 1250 nM
For compound 3 the middle estimate is 8.3-fold (0.92 log units) below the measured one; the measured number lies above the stated range.
By their numbers in this assay, from the lowest: compounds 1 and 2 (each within the scatter of the next); then compound 3.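

Going by these compounds alone, compounds 1 and 2 showed only that one halogen exchange on this aryl ring left the numbers within the scatter of each other. Compound 3 shows that the aryl group on the aromatic nitrogen can still move the result well beyond the scatter in this assay, both against the chloro analogue (a 10-fold higher number from compound 2 to compound 3 (1.02 log units; beyond the scatter)) and against the fluoro analogue (a 20-fold higher number from compound 1 to compound 3 (1.30 log units; beyond the scatter)). The entering 2-chloro-4-(trifluoromethyl)phenyl differs from the leaving 4-chlorophenyl in two features at once, and no data at hand give a reason for this loss of potency.

The compounds shown cannot say whether the chloro or the trifluoromethyl of the entering group carries the step, which would need aryl groups holding only one of the two. Also open, as far as these compounds go, is how this position responds to unsubstituted phenyl or to aryl groups bearing a methoxy, an amine or a carboxylic acid, and whether the step would hold on any core other than the shared one.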